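The source may report more compounds than this note shows. Statements on the series, on what has been measured and on what is new or still open speak of the compounds shown alone.

Compound 1 `C=CC(C)(O)CC[C@@H]1C(=C)CC[C@H](Br)[C@@]1(C)CCC(O)C(C)(C)Cl`: 61000 nM
Compound 2 `C=CC(C)(O)CC[C@@H]1C(=C)CC[C@H](Br)[C@@]1(C)CCC1OC1(C)C`: 57900 nM

In a functional assay on HeLa cells (Homo sapiens) for cytotoxicity, read by MTT assay, with a stated time of 48 h (on this read-out lower numbers stand for stronger inhibition and higher numbers for weaker inhibition), compound 2 can be compared only with compound 1, and the two stand level: a 1.1-fold lower number from compound 1 to compound 2 (0.02 log units; within the scatter).

Compound 3 `C=CC(C)(O)CC[C@@H]1C(=C)CC[C@H](Br)[C@@]1(C)CCC(=O)C(C)C` keeps the shared core and changes one group: isopropylcarbonyl in place of 3,3-dimethyloxiran-2-yl on a saturated chain carbon, two bonds along the chain from a saturated ring carbon. It carries isopropylcarbonyl in place of 3,3-dimethyloxiran-2-yl on a saturated chain carbon, two bonds along the chain from a saturated ring carbon.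

Going by the values given here, the step from compound 1 to compound 2 changed the same place and is the only guide, so it is thin evidence. Among the compounds with values here, no compound with isopropylcarbonyl has been measured yet.

The estimated change is a 1.1-fold lower number from compound 2 to compound 3 (0.02 log units; within the scatter), so no step beyond the scatter is expected. For compound 3 the expected value is 55000 nM, with an estimated range of 25000 nM to 110000 nM.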

Compound 3, half-maximal inhibitory concentration: 71400 nM
The estimate for compound 3 lay 1.3-fold (0.11 log units) below the measured number; the measured number falls inside the stated range.
By their numbers in this assay, from the lowest: compounds 2, 1 and 3 (each within the scatter of the next).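

In this assay, putting isopropylcarbonyl in place of the ring-bearing 3,3-dimethyloxiran-2-yl gives a 1.2-fold higher number from compound 2 to compound 3 (0.09 log units; within the scatter), and putting it in place of 2-chloro-1-hydroxy-2-methylpropyl gives a 1.2-fold higher number from compound 1 to compound 3 (0.07 log units; within the scatter). This place on the chain has now taken three different groups, one of them with no ring, and all three compounds stand level. No supporting measurement is available to explain this result. As far as these compounds go, whether an amine, a carboxylic acid or a longer chain at this place would produce a step beyond the scatter remains open.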